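This account rests on a few compounds, and the source may have more. Where it says the series, first, only, none or still open, it means among the compounds named here.

Measured in a functional assay on KB cells (Homo sapiens) for antiproliferative activity, read by sulforhodamine B assay, with a stated time of 3 days; a higher number here means that more compound is needed for the effect, a lower number that less compound is needed:
compound 1, `CCC1=C(O)c2c(oc(-c3ccc(CC(C)C)cc3)cc2=O)C(CC)(CC)C1=O`: 29.3 uM
compound 2, `CCC1=C(O)c2c(oc(-c3ccc(OC(F)(F)F)cc3)cc2=O)C(CC)(CC)C1=O`: 36.5 uM
compound 3, `CCC1=C(O)c2c(oc(-c3ccc(Br)cc3)cc2=O)C(CC)(CC)C1=O`: > 48.1 uM

For compound 3 the value is a limit of this assay, not a number, as the limit of > 48.1 uM in this assay, at which 1 of the 3 values shown sits, shows. The change to compound 4, `CCC1=C(O)c2c(oc(-c3ccc(C)c(C)c3)cc2=O)C(CC)(CC)C1=O`, is 3,4-dimethylphenyl in place of 4-bromophenyl on an aromatic carbon. The steps that touch compound 3 are an at least 1.6-fold higher number from compound 1 to compound 3 (0.21 log units; that floor lies within the scatter) and an at least 1.3-fold higher number from compound 2 to compound 3 (0.11 log units; that floor lies within the scatter); both floors sit within the scatter, so compound 3 cannot be set apart from compound 1 or compound 2 on these numbers. Compound 4 is therefore expected to land near the measured compounds, with an estimated step of an at least 1.4-fold lower number from compound 3 to compound 4 (0.16 log units; that floor lies within the scatter) in this assay. Compound 4 is estimated at 33 uM, in the range 15 uM to 70 uM.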

Compound 4, concentration for half-maximal effect: 35.5 uM
Beside the measured number, compound 4's estimate is 1.1-fold (0.03 log units) below it; the measured number falls inside the stated range.
By their numbers in this assay, from the lowest: compounds 1, 4 and 2 (each within the scatter of the next). At a limit, above all of these: compound 3.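

In this assay the change from 4-bromophenyl to 3,4-dimethylphenyl gives an at least 1.3-fold lower number from compound 3 to compound 4 (0.13 log units; that floor lies within the scatter) and so cannot be read as a real gain. Compound 3 remains a limit, not a number: the limit of > 48.1 uM in this assay, at which 1 of the 4 values shown sits. Compound 4 alone among those shown carries two methyl groups on the phenyl ring, and it still gives a measured number that lies within the scatter of those of compound 1 and compound 2.

From the compounds shown here alone, whether any group at this position can move the number beyond the scatter remains open. So does the effect of an amine or a carboxylic acid on this phenyl ring.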